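A few compounds are considered here, and "the series" means these few. Any claim that something is new, unique, unknown or untested is made for them only; others in the source may bear on it.

Working notes on the series, following the step from compound 1 to compound 4. In a functional assay on HEL cells (Homo sapiens) for cytotoxicity (on this read-out lower numbers stand for higher toxicity in this test and higher numbers for lower toxicity in this test), compound 1 (`CO[C@@H]1[C@@H](OC)[C@H](c2ccccc2)O[C@@H]2CO[C@@H](c3ccccc3)O[C@@H]12`) gives "not determined" (no result reported), so the starting point of this step has no number. Compound 3 (`COc1ccc([C@@H]2OC[C@H]3O[C@@H](c4ccccc4)[C@H](OC)[C@@H](OC)[C@@H]3O2)cc1`) is in the same position, with "not determined" (no result reported). Among the compounds with values here, the only numerical reading comes from compound 2 (`O[C@@H]1[C@@H](O)[C@H](c2ccccc2)O[C@@H]2CO[C@@H](c3ccc4ccccc4c3)O[C@@H]12`), at 21 ug/mL, and this single value sets the working level for the estimate.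

Compound 4 (`CO[C@@H]1[C@@H](OC)[C@H](c2ccccc2)O[C@@H]2CO[C@@H](c3ccc(Cl)cc3)O[C@@H]12`) has chloro in place of hydrogen on an aromatic carbon, para to a large group, a change from phenyl to 4-chlorophenyl: chloro in place of hydrogen on an aromatic carbon. Within the data shown here, no pair of measured compounds shows the size of this change. With no direction favoured, a step no larger than the usual scatter in this assay is expected, although the missing value for compound 1 leaves this untestable. The range is kept wide, since it rests on one number. For compound 4 the expected value is 35 ug/mL, with an estimated range of 10 ug/mL to 100 ug/mL.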

Compound 4, half-maximal cytotoxic concentration: > 50 ug/mL
Compound 4: no number, only a limit (the forecaster's own chance of this, stated with the estimate: 40%); middle value at least 1.4-fold (0.15 log units) from the limit.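

Compound 4 gives > 50 ug/mL, which is a limit of the assay and not a number. Compound 1 has no single number either, so no step can be read from compound 1 to compound 4. The compounds shown leave open how large the change from phenyl to 4-chlorophenyl is on this read-out.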